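The compounds below may be only part of what the source reports. "The series", "measured", "known", "first", "only" and "open" are said of these compounds alone.

Within the data shown here, compound 3 `CCc1ccc(C(=O)NN(C(=O)c2ccccc2Cl)C(C)(C)C)cc1` stands at the low end of the three numbers so far: in an assay on cells for agonist activity at ecdysone receptor (Bombyx mori), read by a luciferase reporter, with a stated time of 24 h (on this read-out lower numbers stand for an effect already at smaller amounts and higher numbers for an effect only at larger amounts of compound), compound 3 gives 5.75 nM, and its steps to both other compounds lie beyond the scatter, so it is the most potent of the measured set. Compound 1 `CC(C)(C)N(NC(=O)c1ccccc1Br)C(=O)c1ccccc1Cl` gives 316 nM in this assay, and compound 2 `CC(C)(C)N(NC(=O)c1cccc(Br)c1)C(=O)c1ccccc1Cl` gives 191 nM; the step of a 1.7-fold lower number from compound 1 to compound 2 (0.22 log units; within the scatter) is within the scatter, whereas a 55-fold lower number from compound 1 to compound 3 (1.74 log units; beyond the scatter) and a 33-fold lower number from compound 2 to compound 3 (1.52 log units; beyond the scatter) are both large.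

Compound 4 `Cc1ccc(C(=O)NN(C(=O)c2ccccc2Cl)C(C)(C)C)cc1C` has not yet been measured in this assay. It differs from compound 3 by 3,4-dimethylphenyl in place of 4-ethylphenyl on a carbonyl carbon. Among the measured compounds shown here, no measured step changes one alkyl pattern for another on this ring; the only step that keeps the substituent and moves it, from compound 1 to compound 2, was within the scatter, while the two large steps exchanged a bromo substituent for an ethyl group. Compound 4 is therefore expected to stay close to compound 3, with a step of a 2.1-fold higher number from compound 3 to compound 4 (0.32 log units; beyond the scatter) that may not exceed the scatter. Compound 4 is estimated at 12 nM, within a range from 3 nM to 50 nM.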

Compound 4, half-maximal effective concentration: 87.1 nM
Beside the measured number, compound 4's estimate is 7.3-fold (0.86 log units) below it, and the stated range ends below it.
By their numbers in this assay, from the lowest: compound 3; then compound 4; then compounds 2 and 1 (each within the scatter of the next).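

In this assay, rearranging the same carbon count on this carbonyl carbon matters a great deal: 3,4-dimethylphenyl in place of 4-ethylphenyl gives a 15-fold higher number from compound 3 to compound 4 (1.18 log units; beyond the scatter), although the heavy atoms, ring, donors and acceptors counted for the two groups are the same. Compound 4 still compares well with the bromophenyl compounds, with a 2.2-fold lower number from compound 2 to compound 4 (0.34 log units; beyond the scatter) and a 3.6-fold lower number from compound 1 to compound 4 (0.56 log units; beyond the scatter), both modest steps beside the large one from compound 3. Nothing at hand bears on why these two arrangements of carbon differ so much.

The compounds shown leave open whether 4-methylphenyl or a longer chain such as 4-propylphenyl would stay near compound 3 or fall toward compound 4. They also leave open how an amine or a carboxylic acid on this ring would fare.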